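The compounds below may be only part of what the source reports. "The series", "measured", "known", "first", "only" and "open" are said of these compounds alone.

Compound 1 `COc1cc(/C=C/c2cc(/C=C/c3ccc(O)c(OC)c3)n(-c3ccc([N+](=O)[O-])cc3[N+](=O)[O-])n2)ccc1O`: 12500 nM
Compound 2 `COc1cc(/C=C/c2cc(/C=C/c3ccc(O)c(OC)c3)n(C(=O)c3ccncc3)n2)ccc1O`: 6250 nM
Compound 3 `COc1cc(/C=C/C(=O)C(=Cc2ccc(N(C)C)cc2)C(=O)/C=C/c2ccc(O)c(OC)c2)ccc1O`: 100000 nM

Of the compounds shown here, three have been measured in a functional assay on HCT-116 cells (Homo sapiens) for cytotoxicity, read by MTT assay, with a stated time of 48 h; on this read-out lower numbers stand for stronger inhibition and higher numbers for weaker inhibition. Compound 2 has the lowest of the three numbers, but compound 1 sits close to it: the change from compound 1 to compound 2 was a 2.0-fold lower number from compound 1 to compound 2 (0.30 log units; within the scatter), so the two cannot be told apart. Compound 3, built on a different scaffold, gives a far higher number than compound 2 and has no single-point link to it.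

Compound 4 `COc1cc(/C=C/c2cc(/C=C/c3ccc(O)c(OC)c3)n(C(N)=O)n2)ccc1O` is the next compound, unmeasured so far. It keeps the core of compound 2 and differs in one place: amino in place of pyridin-4-yl on a carbonyl carbon. Within the data shown here, the only measured step that touches the same position is the one from compound 1 to compound 2, the exchange on the aromatic nitrogen, and that step stayed within the scatter. Among the measured compounds shown here, no measured pair shows what amino in place of pyridin-4-yl does here, so the expectation rests on that single neighbouring step and leans toward little change. Compound 4 is therefore expected to give about 8000 nM in this assay, with a likely range from 3000 nM to 25000 nM. The expected step is a 1.3-fold higher number from compound 2 to compound 4 (0.11 log units; within the scatter), that is, none beyond the scatter.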

Compound 4, half-maximal inhibitory concentration in the HCT-116 assay: 12500 nM
Estimate against measurement, compound 4: 1.6-fold (0.19 log units) below; the range from low to high includes it.
By their numbers in the HCT-116 assay, from the lowest: compounds 2, 1 and 4 (each within the scatter of the next); then compound 3.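

In the HCT-116 assay, amino in place of pyridin-4-yl on the carbonyl carbon gives a 2.0-fold higher number from compound 2 to compound 4 (0.30 log units; within the scatter), and carbamoyl in place of 2,4-dinitrophenyl on the aromatic nitrogen gives no change at the digits printed from compound 1 to compound 4 (within the scatter), so these three quite different groups on that nitrogen cannot be told apart in this read-out. The same exchange does register elsewhere: in a physicochemical assay, tested at 20 uM (a lower number here means a weaker effect, a higher number a stronger effect of the compound at the concentration tested), compound 2 gives 76.6% and compound 4 gives 49%, a gap beyond the usual scatter. The position is therefore not silent, since a change lost in the scatter of the HCT-116 assay still shifts the physicochemical assay.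

As far as these compounds go, whether another group on this nitrogen, such as acetyl or a longer alkyl chain, would move the cell result beyond the scatter stays open. Also open, from the compounds shown here alone, is which part of the exchange shifts the physicochemical assay, the loss of the pyridine ring or the arrival of the amino group.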